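The source may hold more compounds than are shown below. What is called first, only, known or untested is meant among the compounds shown, and "the series" means these compounds.

Among the compounds with values here, compound 2 `CCCCCC(=O)NCC(=O)N[C@@H]1[C@@H](O)[C@H](O)[C@@H](Nc2ncnc3[nH]cnc23)O[C@H]1C` gives 250000 nM in a functional assay on L1210 cells (Mus musculus) for cytotoxicity (a lower number here means a stronger inhibitor, a higher number a weaker inhibitor), the only plain number in the set. Compound 1 `CC(C)CCCCCCCCCCCCC(=O)NCC(=O)N[C@@H]1[C@@H](O)[C@H](O)[C@@H](Nc2ncnc3[nH]cnc23)O[C@H]1CO` in this assay returns > 10000 nM, which is a limit of the assay and not a number. Compound 3 `CC(C)CCCCCCCCCCCCC(=O)NCC(=O)N[C@@H]1[C@@H](O)[C@H](O)[C@@H](Nc2ncnc3[nH]cnc23)O[C@H]1C` is not yet measured; it differs from compound 2 by 8-methylnonyl in place of hydrogen on a saturated chain carbon, five bonds along the chain from a carbonyl carbon. Within the data shown here, no step between two measured compounds is available, so the size of this change has no measured precedent here. Compound 3 is expected at 50000 nM, within 10000 nM to 250000 nM. The estimated step of a 5.0-fold lower number from compound 2 to compound 3 (0.70 log units; beyond the scatter) is expected toward stronger inhibition, beyond the scatter.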

Compound 3, half-maximal inhibitory concentration: > 20000 nM
Compound 3: a limit, no number; the forecaster's own chance of this, stated with the estimate: 35%; the middle value does not contradict the limit.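

The steps from compound 2 to compound 3 and from compound 1 to compound 3 cannot be read, because compound 3 stands at a limit and not a number: the limit of > 20000 nM in this assay, at which 1 of the 3 values shown sits.

Open: what size of change, if any, 8-methylnonyl in place of hydrogen or hydrogen in place of hydroxy brings in this assay.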